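One Stereocentre Inverted on a Shared Core

A few compounds are considered here, and "the series" means these few. Any claim that something is new, unique, unknown or untested is made for them only; others in the source may bear on it.

Going by the values given here, compound 3 `O=C(c1ccc(O)cc1O)[C@@H]1[C@H](C(=O)c2ccc(O)cc2O)[C@@H](c2ccccc2)[C@H]1c1ccccc1` stands second highest of the three numbers known so far: in a functional assay on PC-3 cells (Homo sapiens) for cytotoxicity, read by MTT assay, with a stated time of 48 h, tested at 5 uM (on this read-out lower numbers stand for a weaker effect and higher numbers for a stronger effect at the one concentration tested), compound 3 gives 27.1%, while compound 1 `O=C(c1ccc(O)cc1O)[C@H]1[C@H](c2ccccc2)[C@H](C(=O)c2ccc(O)cc2O)[C@H]1c1ccccc1` gives 29.6% and compound 2 `O=C(c1ccc(O)cc1O)[C@H]1[C@H](c2ccccc2)[C@H](C(=O)c2ccc(O)cc2O)[C@@H]1c1ccccc1` gives 12.3%. Compound 4 `O=C(c1ccc(O)cc1O)[C@@H]1[C@@H](C(=O)c2ccc(O)cc2O)[C@H](c2ccccc2)[C@@H]1c1ccccc1` differs from compound 3 only in this way: the two compounds have the same atoms and bonds and differ only in configuration as drawn: 1 of 4 stereo elements differ; a stereocentre at a saturated ring carbon is drawn R in compound 3 and S in compound 4. Among the compounds with values here, the one measured step that bears on a change of configuration is a number 17.3 percentage points lower from compound 1 to compound 2 (beyond the scatter), and that pair is informative because of the fact that compounds 1 and 2 differ only in the configuration as drawn. Two stereo elements moved there, whereas only one moves here, so a smaller downward step is expected, a number 7.1 percentage points lower from compound 3 to compound 4 (within the scatter), which may yet remain within the scatter. Compound 4 is therefore estimated to give 20%, between 8% and 32%.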

Compound 4, a percentage reported as activity, at one concentration (the size of the read-out at that concentration, not a potency): 29%
For compound 4 the middle estimate is 9 percentage points below the measured one; the range from low to high includes it.
By their numbers in this assay, from the lowest: compound 2; then compounds 3, 4 and 1 (each within the scatter of the next).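

The inversion at this one saturated ring carbon gives a number 1.9 percentage points higher from compound 3 to compound 4 (within the scatter) in this assay. Set beside the change of two stereo elements, which gave a number 17.3 percentage points lower from compound 1 to compound 2 (beyond the scatter), it shows that a change of configuration on the shared core does not always bring a step beyond the scatter: the fact that compounds 3 and 4 differ only in the configuration as drawn

Which of the two stereo elements that differ in compound 2 accounts for its lower number stays open. Also open, as far as these compounds go, is how the read-out would respond to an amine or a carboxylic acid on the shared core.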